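Anilide series against Rho kinase: bromophenyl to aminophenyl

The compounds below may be only part of what the source reports. "The series", "measured", "known", "first", "only" and "open" are said of these compounds alone.

Measured so far:
compound 1, `CN(C)c1ccc(C(=O)Nc2cccc(NC(=O)COc3ccc4occc(=O)c4c3)c2)cc1`, > 10000 nM (a limit of the assay)
compound 2, `Cc1coc2cc(OCC(=O)Nc3cccc(NC(=O)c4ccc(N(C)C)cc4)c3)ccc2c1=O`, > 10000 nM (a limit of the assay)
compound 3, `O=C(COc1ccc2c(=O)ccoc2c1)Nc1cccc(NC(=O)c2ccc(Br)cc2)c1`, 303 nM

Going by the values given here, in an assay on isolated protein for inhibition of Rho-associated protein kinase 1 (Homo sapiens), read by scintillation counting, radiometric assay and 33P incorporation, with a stated time of 40 min, in the presence of a further agent that is not named here (on this read-out higher numbers stand for weaker inhibition and lower numbers for stronger inhibition), compound 3 gives 303 nM, the only numeric value in the set. Compound 1 gives only a limit, > 10000 nM. Compound 2 likewise gives only a limit, > 10000 nM. Among the compounds with values here, compound 3 therefore stands alone as the one member with measurable inhibition; the two others sit at the limit of > 10000 nM in this assay, at which 2 of the 3 values shown sit.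

Compound 4, `Nc1cccc(C(=O)Nc2cccc(NC(=O)COc3ccc4c(=O)ccoc4c3)c2)c1`, has not yet been tested in this assay. It differs from compound 3 in one place: 3-aminophenyl in place of 4-bromophenyl on a carbonyl carbon. Within the data shown here, no step between measured compounds is recorded, so nothing directly calibrates this change.

The expectation rests on the shape of the set: both compounds bearing a nitrogen-substituted phenyl on the benzamide end, compound 1 and compound 2, return only a limit in this assay, while the bromophenyl compound 3 gives a number. Compound 4 is therefore expected to lose potency, with a step of a 9.9-fold higher number from compound 3 to compound 4 (1.00 log units; beyond the scatter) estimated from compound 3, and a real chance that the assay again reports only a limit. The estimate for compound 4 in this assay is 3000 nM, within a range from 600 nM to 15000 nM.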

Compound 4, half-maximal inhibitory concentration: 670 nM
For compound 4 the middle estimate is 4.5-fold (0.65 log units) above the measured one; low and high end bracket the measured number.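

In this assay, going by these compounds alone, replacing 4-bromophenyl with 3-aminophenyl on this carbonyl carbon gives a 2.2-fold higher number from compound 3 to compound 4 (0.34 log units; beyond the scatter), a modest step that is the first calibrated change at this place. The bromine is therefore not required for a measurable number here, and this position tolerates a swap from a group with no hydrogen-bond donors or acceptors to one carrying one of each, at a modest cost. Within the data shown here, compound 4 is also the first compound with a nitrogen on this phenyl to return a number, while the compounds held at the limit differ from it in more than one place, so that limit cannot be assigned to the presence of nitrogen alone: the limit of > 10000 nM in this assay, at which 2 of the 4 values shown sit.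

This single step changes both the substituent and where it sits on the phenyl, so the share of each in the difference remains unresolved. A 3-bromophenyl or a 4-aminophenyl group on the same carbonyl carbon would separate the two, and a 3-(dimethylamino)phenyl group would test whether the substituted amine behaves like the free one in this core.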